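Same four-atom group for three-atom group, two cores

The source may hold more compounds than are shown below. What is called first, only, known or untested is meant among the compounds shown, and "the series" means these compounds.

Compound 1, `Cc1ccc(-c2nnc([S+](C)[O-])n2C)cc1`, gives in a functional assay on the whole organism for antagonist activity, with Mus musculus as the target, in the maximal electroshock model (on this read-out higher numbers stand for an effect only at larger amounts of compound and lower numbers for an effect already at smaller amounts), only the limit > 200 mg/kg.
Compound 2, `Cc1ccc(-c2nnc(S(C)(=O)=O)n2C)cc1`, gives in this assay only the limit > 200 mg/kg.
Compound 3, `Cn1c(-c2ccccc2F)nnc1[S+](C)[O-]`, gives in this assay only the limit > 200 mg/kg.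

The change from compound 1 to compound 2 is a group of 4 heavy atoms (1 carbon, 2 oxygen, 1 sulfur; no ring) in place of a group of 3 heavy atoms (1 carbon, 1 oxygen, 1 sulfur; no ring), on an aromatic carbon. Its size in this assay is a step that the two limits leave unreadable from compound 1 to compound 2, and both values are limits of the assay rather than numbers. The difference between the core of compound 1 and the core of compound 3 is not broken down here. Compound 4, `Cn1c(-c2ccccc2F)nnc1S(C)(=O)=O`, is not yet measured; it differs from compound 3 by a group of 4 heavy atoms (1 carbon, 2 oxygen, 1 sulfur; no ring) in place of a group of 3 heavy atoms (1 carbon, 1 oxygen, 1 sulfur; no ring), on an aromatic carbon, the same change as that from compound 1 to compound 2. Among the measured compounds shown here, the only evidence at hand is the limit of > 200 mg/kg in this assay, at which 3 of the 3 values shown sit. On that ground compound 4 is expected to sit at the same limit, with an estimated step that the limit leaves unreadable from compound 3 to compound 4 from compound 3 in this assay. The estimate for compound 4 in this assay is 300 mg/kg, between 150 mg/kg and 1000 mg/kg.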

Compound 4, dose for half-maximal effect: > 100 mg/kg
Compound 4 gave a limit, no number; the forecaster's own chance of this, stated with the estimate: 85%; the middle value lies beyond the limit too.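

Compound 3 and compound 4 both give only limits of this assay rather than numbers, so no step can be read between them. The compounds shown leave open whether any of them reaches a half-maximal effect at a readable dose, and whether methylsulfonyl in place of the three-atom group shifts that dose on either core.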